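This account rests on a few compounds, and the source may have more. Where it says the series, first, only, none or still open, it means among the compounds named here.

Working notes on the series, measured in an ADME assay on BaF3 cells (Mus musculus) for cytotoxicity, read by MTT assay, with a stated time of 48 h; a lower number here means a stronger inhibitor of growth, a higher number a weaker inhibitor of growth:

- compound 1 `CC(C)n1nc(-c2cc(C3CCCCC3)on2)c2c(N)ncnc21`: > 10000 nM (a limit)
- compound 2 `CC(C)n1nc(-c2cc(C(C)(C)C)on2)c2c(N)ncnc21`: > 10000 nM (a limit)
- compound 3 `CC(C)(O)Cn1nc(-c2cc(C3CC3)on2)c2c(N)ncnc21`: > 10000 nM (a limit)

Compound 3 stands at > 10000 nM, which is a limit and not a number. It therefore gives no exact starting point for the next step. The other two compounds offer no readable value either, as the limit of > 10000 nM in this assay, at which 3 of the 3 values shown sit, shows, and none of the three goes against this.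

Compound 4 `Cn1nc(-c2cc(C3CC3)on2)c2c(N)ncnc21` is the next compound to be measured in this assay. The change is hydrogen in place of 1-hydroxy-1-methylethyl on a saturated chain carbon bound to an aromatic nitrogen, which also reads as 2-hydroxy-2-methylpropyl to methyl.

Within the data shown here, the only measured step is a step that the two limits leave unreadable from compound 1 to compound 2. It concerns a change at a different place, on an aromatic carbon, and provides no size or direction to carry over. Among the measured compounds shown here, no measured step covers the present change.

With compound 3 at > 10000 nM, the working expectation is that the new compound also stays at the limit, with no readable step beyond the scatter. The expected step is a number no higher from compound 3 to compound 4 (the limit leaves the size open).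

For compound 4 the estimate is 10000 nM, with an expected range of 4000 nM to 20000 nM.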

Compound 4, concentration for 50% growth inhibition: > 10000 nM
Compound 4: a limit, no number; the forecaster's own chance of this, stated with the estimate: 75%; the middle value lies on the limit itself.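

In this assay compound 4 gives > 10000 nM, which is a limit and not a number. Compound 3 is also at a limit, so no step can be read between compound 3 and compound 4. The compounds shown leave open how the changes in the series affect growth inhibition, as all of them sit at one limit: the limit of > 10000 nM in this assay, at which 4 of the 4 values shown sit.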